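Chain extension at the ring amine: cytotoxicity working notes

The compounds below may be only part of what the source reports. "The series", "measured", "known", "first", "only" and "open" are said of these compounds alone.

Of the compounds shown here, two so far have a cytotoxicity read-out in an ADME assay on HeLa cells (Homo sapiens) for cytotoxicity, read by microscopy, with a stated time of 6 days; on this read-out lower numbers stand for higher toxicity in this test and higher numbers for lower toxicity in this test. Compound 1 `CCCCCCNc1cncc(C(=O)NCc2ccccc2)n1` reaches only the limit of the test; in this assay compound 1 gives > 100000 nM, a limit and not a number. Compound 2 `CCCCNc1nccnc1C(=O)NCc1ccccc1` sits at the same limit; in this assay compound 2 gives > 100000 nM, again a limit rather than a measured value. Where compound 2 stands is thus fixed only from one side: both results shown sit at the limit of > 100000 nM in this assay, at which 2 of the 2 values shown sit, so no step between measured compounds can be computed, and no direction of change within the measured set is known.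

Compound 3 `CCCCCCCNc1nccnc1C(=O)NCc1ccccc1` is the next member to be measured. It differs from compound 2 by propyl in place of hydrogen on a saturated chain carbon, four bonds along the chain from a nitrogen on an aromatic ring. Among the compounds with values here, since the only measured values both rest at the limit of > 100000 nM in this assay, at which 2 of the 2 values shown sit, there is no measured basis for a shift in either direction. The expected step is a number no higher from compound 2 to compound 3 (the limit leaves the size open), that is, none beyond the scatter. Compound 3 is expected to give 100000 nM, with a range from 30000 nM to 300000 nM, and most probably once more only a limit.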

Compound 3, minimum cytotoxic concentration: > 100000 nM
Compound 3: only a limit was reported; the forecaster's own chance of this, stated with the estimate: 70%; the middle value sits exactly at the limit.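

In this assay compound 3 gives > 100000 nM, a limit and not a number. Compound 2 also rests on a limit, so no step can be read between compound 2 and compound 3. The compounds shown leave open whether the longer chain changes the read-out at all, and what true value any of them has: the limit of > 100000 nM in this assay, at which 3 of the 3 values shown sit.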